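Aryl swap on the saturated hexyl thioether citrate series

The compounds below may be only part of what the source reports. "The series", "measured", "known", "first", "only" and "open" are said of these compounds alone.

Going by the values given here, compound 1 `O=C(O)CC(O)(CSCCCCCCc1cccc(Cl)c1)C(=O)O` is the weaker of the two measured members. In an assay on isolated protein for inhibition of ATP-citrate synthase (Rattus norvegicus) (on this read-out lower numbers stand for stronger inhibition and higher numbers for weaker inhibition), compound 1 gives 150000 nM, the highest number recorded so far, and compound 2 `O=C(O)CC(O)(CSCCCC/C=C/c1ccc(Cl)cc1Cl)C(=O)O` gives 7400 nM in this assay, a markedly lower number; the two differ in both the chain and the aryl group, so no single-step comparison is drawn from them.

Compound 3 `O=C(O)CC(O)(CSCCCCCCc1ccc(F)cc1)C(=O)O` is not yet measured. It differs from compound 1 by 4-fluorophenyl in place of 3-chlorophenyl on a saturated chain carbon, six bonds along the chain from a sulfur. Among the compounds with values here, both halogenated phenyl groups carry the same heavy-atom count, with no hydrogen-bond donors or acceptors and no charge; the only changes are the halogen itself and the ring position named above.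

Within the data shown here, nothing among the measured compounds isolates the effect of this swap. The expectation is a small change in this assay, if any, with no clear direction, and most likely one that stays within the usual scatter. On that basis the step from compound 1 to compound 3 is estimated as a 1.2-fold higher number from compound 1 to compound 3 (0.08 log units; within the scatter). Compound 3 is expected to give 180000 nM, with a plausible range from 60000 nM to 550000 nM.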

Compound 3, inhibition constant: 120000 nM
Beside the measured number, compound 3's estimate is 1.5-fold (0.18 log units) above it, and the stated range covers the measured number.
By their numbers in this assay, from the lowest: compound 2; then compounds 3 and 1 (each within the scatter of the next).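

In this assay, 4-fluorophenyl in place of 3-chlorophenyl on a saturated chain carbon, six bonds along the chain from a sulfur, gives a 1.3-fold lower number from compound 1 to compound 3 (0.10 log units; within the scatter). Going by these compounds alone, this is the first single-place comparison: the halogen and its ring position change together here, and the number does not move beyond the scatter, which compound 2 could not show because it differs from compound 1 and compound 3 in both the chain and the aryl group. No measurement at hand bears on the reason for this result.

With both features changed in one step, the separate contribution of each stays unresolved, and it remains possible that they offset each other; a 4-chlorophenyl group on the same saturated chain would separate them. Also open, going by these compounds, is whether a phenyl ring carrying an amine or a carboxylic acid, or a longer chain in place of the hexyl chain, would move the number beyond the scatter.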